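The compounds below may be only part of what the source reports. "The series", "measured", "known", "first", "only" and "open" are said of these compounds alone.

Working notes on the coumarin-type series, all numbers from an assay on isolated protein (strain Sprague-Dawley) for inhibition of Amine oxidase [flavin-containing] B (Rattus norvegicus), read by spectrophotometry, with a stated time of 5 min; a lower number here means a stronger inhibitor, a higher number a weaker inhibitor.

Compound 1 `COc1cc(=O)oc2cc(OCc3cccc(Br)c3)ccc12` gives 5.75 nM in this assay. Compound 2 `CC(=O)COc1cc(=O)oc2cc(OCc3cccc(Cl)c3)ccc12` gives 26.9 nM in this assay, the highest of the two single numbers measured, with compound 1 lower. Compound 3 `NC(=O)COc1cc(=O)oc2cc(OCc3cccc(Cl)c3)ccc12` has been run more than once in this assay and gives 3.1 nM; 3.31 nM (2 entries), the repeat entries of compound 3 agreeing closely (the several entries of compound 3 in this assay, 3.1 nM; 3.31 nM (2 entries)); both of its entries sit below compound 2. Within the data shown here, no pair among compounds 1, 2 and 3 differs in one place only, so no single measured step can be read from them.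

Compound 4 `O=C(COc1cc(=O)oc2cc(OCc3cccc(Cl)c3)ccc12)N1CCCCC1` has not yet been measured in this assay. It differs from compound 2 by piperidin-1-yl in place of methyl on a carbonyl carbon. Among the measured compounds shown here, no measured step in this assay matches that change. Compound 4 is expected to land somewhat below compound 2, since the amide compound 3 gives 3.1 nM; 3.31 nM (2 entries) in this assay; the step from compound 2 to compound 4 is estimated as a 2.7-fold lower number from compound 2 to compound 4 (0.43 log units; beyond the scatter), near the edge of the scatter. For compound 4 the expected value in this assay is 10 nM, with a range from 3 nM to 35 nM.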

Compound 4, half-maximal inhibitory concentration: 38900 nM
Compound 4: the middle estimate sits 3900-fold (3.59 log units) below what was measured, and the stated range ends below it.
By their numbers in this assay, from the lowest: compound 1; then compound 2; then compound 4.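

In this assay, the position on the carbonyl carbon turns out to be far from indifferent to what it carries: piperidin-1-yl in place of methyl gives a 1400-fold higher number from compound 2 to compound 4 (3.16 log units; beyond the scatter), the first single-place step read in the series, and a large one. The change brings in a six-membered non-aromatic ring with 6 heavy atoms where methyl had 1, and it adds no hydrogen-bond donors or acceptors. A carbonyl bearing nitrogen is not enough by itself to explain the loss, because the primary amide compound 3 stays at low numbers: the several entries of compound 3 in this assay, 3.1 nM; 3.31 nM (2 entries)

From the compounds shown here alone, whether the loss follows the ring or any substitution on the amide nitrogen remains open. Methylamino and dimethylamino on the same carbonyl carbon would separate these two readings, and pyrrolidin-1-yl or morpholin-4-yl would show how far the loss depends on the ring itself.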